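The source may report more compounds than this note shows. Statements on the series, on what has been measured and on what is new or still open speak of the compounds shown alone.

The three measured compounds share one core and differ only at the amide-type nitrogen on the carbonyl carbon. Compound 1 `CCN(CC)C(=O)[C@@H]1CCCN(S(=O)(=O)c2ccc(S(=O)(=O)N(CC)CC)cc2)C1` gives 6400 nM in a functional assay on MIA PaCa-2 cells (Homo sapiens) for inhibition, read by MTT assay, with a stated time of 7 days; on this read-out higher numbers stand for weaker inhibition and lower numbers for stronger inhibition. Compound 2 `CCN(CC)S(=O)(=O)c1ccc(S(=O)(=O)N2CCC[C@@H](C(=O)NC3COC3)C2)cc1` gives 2300 nM in this assay, and compound 3 `CCN(CC)S(=O)(=O)c1ccc(S(=O)(=O)N2CCC[C@@H](C(=O)NC)C2)cc1` gives 8600 nM. Compound 3 sits at the high end of these three numbers; against compound 1 the difference is within the scatter, while a 3.7-fold higher number from compound 2 to compound 3 (0.57 log units; beyond the scatter). Compound 4 `CCN(CC)S(=O)(=O)c1ccc(S(=O)(=O)N2CCC[C@@H](C(=O)NC3CN(C(=O)OC(C)(C)C)C3)C2)cc1` differs from compound 3 in that (1-(tert-butoxycarbonyl)azetidin-3-yl in place of methyl on an amide-type nitrogen). The step that bears most directly on this change is a 3.7-fold higher number from compound 2 to compound 3 (0.57 log units; beyond the scatter), read in reverse: exchanging methyl for a four-membered ring gave a modestly lower number. a 2.8-fold lower number from compound 1 to compound 2 (0.44 log units; beyond the scatter) adds that the four-membered ring produced the lowest of the three numbers, whereas a 1.3-fold higher number from compound 1 to compound 3 (0.13 log units; within the scatter). A four-membered ring with one hetero atom enters again here, so a modest lowering is expected, a 3.1-fold lower number from compound 3 to compound 4 (0.49 log units; beyond the scatter). Compound 4 is therefore estimated at 2800 nM, with a range from 900 nM to 8000 nM.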

Compound 4, half-maximal inhibitory concentration: 200 nM
Beside the measured number, compound 4's estimate is 14-fold (1.15 log units) above it, outside the stated range (below it).
By their numbers in this assay, from the lowest: compound 4; then compound 2; then compounds 1 and 3 (each within the scatter of the next).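

Among these compounds, this amide-type nitrogen accepts a much larger group than the earlier compounds showed: 1-(tert-butoxycarbonyl)azetidin-3-yl in place of methyl brings a 43-fold lower number from compound 3 to compound 4 (1.63 log units; beyond the scatter) and so goes well beyond the modest steps seen before. A four-membered ring with one hetero atom is not enough to explain the new result, since oxetan-3-yl also carries one and the exchange for the new group still brings a 12-fold lower number from compound 2 to compound 4 (1.06 log units; beyond the scatter) as a large step, while the exchange on the carbonyl carbon brings a 32-fold lower number from compound 1 to compound 4 (1.51 log units; beyond the scatter) and is just as clearly large. Nothing measured here gives a reason for the size of these steps.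

On these data alone, it remains open whether the tert-butoxycarbonyl group or the azetidine ring carries the fall. A free azetidin-3-yl amine, or an acetyl group on that ring nitrogen, would separate the two.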